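This account rests on a few compounds, and the source may have more. Where it says the series, first, only, none or still open, it means among the compounds named here.

Measured in a functional assay on KB cells (Homo sapiens) for cytotoxicity, read by MTT assay, with a stated time of 72 h; on this read-out lower numbers stand for stronger inhibition and higher numbers for weaker inhibition:
- compound 1 `Cc1ccc(S(=O)(=O)c2nc3ccccc3nc2N2CCc3ccccc3C2)cc1`: 32100 nM
- compound 2 `Cc1ccc(S(=O)(=O)c2nc3ccccc3nc2N2CCCC(O)C2)cc1`: 6080 nM

Of these two compounds, compound 2 has the lower number, at 6080 nM. Compound 3 `O=S(=O)(c1ccc(F)cc1)c1nc2ccccc2nc1N1CCCC(O)C1` differs from compound 2 by fluoro in place of methyl on an aromatic carbon, with fluoro in place of methyl on an aromatic carbon, para to a large group. Going by the values given here, the only measured step, a 5.3-fold lower number from compound 1 to compound 2 (0.72 log units; beyond the scatter), replaces 1,2,3,4-tetrahydroisoquinolin-2-yl with 3-hydroxypiperidin-1-yl. It concerns a different place in the molecule, so it gives no direct guide to this change. Among the compounds with values here, no measured compound varies the 4-methylphenyl group, so no direction can be drawn from the data, and no step beyond the scatter is expected in this assay. The expected change is a 1.1-fold higher number from compound 2 to compound 3 (0.03 log units; within the scatter). For compound 3 the estimated value is 6500 nM, with an expected range from 2700 nM to 15000 nM.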

Compound 3, half-maximal inhibitory concentration: 18300 nM
The estimate for compound 3 lay 2.8-fold (0.45 log units) below the measured number; the measured number lies above the stated range.
By their numbers in this assay, from the lowest: compound 2; then compounds 3 and 1 (each within the scatter of the next).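

In this assay, the 4-methylphenyl group turns out not to be a neutral place in the molecule: going to 4-fluorophenyl, with 3-hydroxypiperidin-1-yl held fixed, gives a 3.0-fold higher number from compound 2 to compound 3 (0.48 log units; beyond the scatter) and so moves the number beyond the scatter. Going by these compounds alone, the earlier compounds varied only the group that carries the hydroxyl, so this is the first sign that the aromatic carbon para to a large group also matters on this read-out, with methyl giving the lower number of the two. Nothing at hand explains why exchanging one heavy atom for another has this effect.

On these data alone, whether the rise is specific to fluoro stays open, since hydrogen, chloro, methoxy or an amine at this place could fall on either side of methyl. As far as these compounds go, it is also open whether the same change would run the same way with 1,2,3,4-tetrahydroisoquinolin-2-yl on the core.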